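Exchanging the Aryl Group on the Double-Bonded Carbon

The source may hold more compounds than are shown below. What is called first, only, known or untested is meant among the compounds shown, and "the series" means these compounds.

Of the compounds shown here, two of one shared core have so far been tested in a functional assay on HeLa cells (Homo sapiens) for cytotoxicity, read by MTT assay, with a stated time of 48 h, tested at 25 uM; a lower number here means a weaker effect, a higher number a stronger effect of the compound at the concentration tested. Compound 1 `CSc1ccc(/C=N/n2c(Cc3ccc(S(C)(=O)=O)cc3)n[nH]c2=S)cc1` gives 32.7%, and compound 2 `CS(=O)(=O)c1ccc(Cc2n[nH]c(=S)n2/N=C/c2ccccc2Cl)cc1` gives 36.3%. For the measured compounds named here, the only measured step, a number 3.6 percentage points higher from compound 1 to compound 2 (within the scatter), is therefore no change that can be trusted. On the numbers shown, compound 2 stands at the top of the two, with compound 1 nearest to it, and the gap between them lies within the scatter.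

Compound 3 `CS(=O)(=O)c1ccc(Cc2n[nH]c(=S)n2/N=C/c2cccs2)cc1` is not yet measured. It differs from compound 2 in one place: thiophen-2-yl in place of 2-chlorophenyl on a carbon with a double bond to nitrogen. Going by the values given here, the single step that bears on this change is the one from compound 1 to compound 2, which also replaced the group on that same carbon with a double bond to nitrogen and moved the read-out in this assay by an amount within the scatter. On that basis compound 3 is expected to show a step of a number 2.3 percentage points lower from compound 2 to compound 3 (within the scatter), that is, none beyond the scatter. The estimate for compound 3 in this assay is 34%, within a range from 22% to 46%.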

Compound 3, a percentage reported as activity, at one concentration (the size of the read-out at that concentration, not a potency): 33.3%
Compound 3: middle estimate off by 0.7 percentage points, on the high side; measured number inside the range.
By their numbers in this assay, from the lowest: compounds 1, 3 and 2 (each within the scatter of the next).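

On the carbon with a double bond to nitrogen, thiophen-2-yl in place of 2-chlorophenyl gives, in this assay, a number 3 percentage points lower from compound 2 to compound 3 (within the scatter), and thiophen-2-yl in place of 4-(methylsulfanyl)phenyl gives a number 0.6 percentage points higher from compound 1 to compound 3 (within the scatter). The earlier pair compared only two six-membered aromatic rings of carbon, whereas this result adds a five-membered aromatic ring with a sulfur atom as its hetero atom, and that exchange of ring, with the loss of the chlorine in the step from the 2-chlorophenyl compound, also stays inside the scatter, so the three compounds shown cannot be told apart at this position. Nothing measured on these compounds gives a reason for this result.

Going by these compounds, all three groups at this carbon are aromatic rings, so it remains open whether an amine, a carboxylic acid or a longer alkyl chain in that place would move the read-out beyond the scatter. The three compounds also share the rest of the core and have a single read-out at one concentration, which leaves open both what a change elsewhere on the core would do and how their potencies compare.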